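The compounds below may be only part of what the source reports. "The series", "measured", "known", "first", "only" and "open" are said of these compounds alone.

Measured so far:
Compound 1, `COc1ccc(C(=O)/C=C/c2ccc(OC)c(Br)c2)c(O)c1`, gives 3.8% in an assay on isolated protein for inhibition of DNA topoisomerase 1 (Homo sapiens), tested at 20 uM; a higher number here means a stronger effect of the compound at the concentration tested, a lower number a weaker effect.
Compound 2, `O=C(/C=C/c1ccc(F)cc1)c1ccc(O)cc1O`, gives 56.7% in this assay.
Compound 3, `COc1cc(O)ccc1C(=O)/C=C/c1ccc(F)cc1`, gives 61.6% in this assay.

Compounds 2 and 3 share a core and differ in one place: hydrogen in place of methyl on an oxygen on an aromatic ring. This change gave a number 4.9 percentage points lower from compound 3 to compound 2 (within the scatter), so in this pair the two readings are within the scatter of each other and no direction can be claimed. Compound 1 stands lowest of the three, with compound 2 the nearest to it and compound 3 the furthest; how the core of compound 1 differs from that of compound 3 is not broken down here, the two differing in more than one place.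

Compound 4, `COc1ccc(/C=C/C(=O)c2ccc(O)cc2O)cc1Br`, is not yet measured. It stands to compound 1 as compound 2 stands to compound 3: hydrogen in place of methyl on an oxygen on an aromatic ring. Going by the values given here, the one measured example of this change, between compound 3 and compound 2, stayed within the scatter, and this is the only basis for what can be said about compound 4, since its own core appears only once among the measured compounds. On that basis the step from compound 1 to compound 4 is expected to be small, about a number 2.2 percentage points higher from compound 1 to compound 4 (within the scatter), because of a number 4.9 percentage points lower from compound 3 to compound 2 (within the scatter). Compound 4 is therefore estimated to give roughly 6% in this assay, with a plausible range from 0% to 22%.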

Compound 4, a percentage reported as inhibition, at one concentration (the size of the read-out at that concentration, not a potency): 8.2%
Compound 4: middle estimate off by 2.2 percentage points, on the low side; the measured number falls inside the stated range.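

Replacing methoxy by hydroxy on the core of compound 1 gave a number 4.4 percentage points higher from compound 1 to compound 4 (within the scatter) in this assay, so compound 1 and compound 4 cannot be told apart in this read-out. Set beside the earlier pair, the change reads the same on both cores as far as this assay can show: the same change on two cores in this assay, a number 4.9 percentage points lower (within the scatter) from compound 3 to compound 2 and a number 4.4 percentage points higher (within the scatter) from compound 1 to compound 4, 9.3 percentage points apart, within the scatter of two such steps. In these two pairs, then, hydrogen in place of methyl on an oxygen on an aromatic ring left the reading within the scatter, whether the starting point was compound 3 at 61.6% or compound 1 at 3.8%, but this does not show that the change has no effect at all, as a step smaller than the scatter would go unseen, and two cores say nothing certain about any other core in the series.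

The compounds shown leave open how this read-out would respond if that oxygen carried an ethyl group, a longer chain or an acetyl group, or if an amine or a carboxylic acid stood in its place. They also leave open the separate contributions of the bromine and the second methoxy group of compound 1 and the fluorine of compound 3, as no pair shown changes any of these alone.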